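Lengthening the amino side chain on a shared core

A few compounds are considered here, and "the series" means these few. Any claim that something is new, unique, unknown or untested is made for them only; others in the source may bear on it.

Compound 1 `C[C@H](CO)Nc1nc(C(=O)NCc2ccc(F)cc2)c(O)c2ncccc12` and compound 2 `O=C(NCc1ccc(F)cc1)c1nc(NCCO)c2cccnc2c1O` share one core and differ only in the group on the saturated chain carbon bound to the ring nitrogen. In a functional assay on MDA-MB-435 cells (Homo sapiens) for cytotoxicity, read by MTT assay, with a stated time of 72 h (a higher number here means a weaker inhibitor, a lower number a stronger inhibitor), compound 1 gives only a limit, > 20000 nM. In this assay compound 2 likewise gives only a limit, > 20000 nM. The step that the two limits leave unreadable from compound 1 to compound 2 therefore cannot be read, since (the limit of > 20000 nM in this assay, at which 2 of the 2 values shown sit). Compound 2 thus stands at the edge of the numbers shown, with no measured value of its own.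

Compound 3 `O=CNCCCCCCNc1nc(C(=O)NCc2ccc(F)cc2)c(O)c2ncccc12` carries the change (4-(formylamino)butyl in place of hydroxy on a saturated chain carbon, two bonds along the chain from a nitrogen on an aromatic ring); seen one bond further out, the (2-hydroxyethyl)amino group of compound 2 becomes (6-(formylamino)hexyl)amino. Among the measured compounds shown here, no readable step bears on this change in this assay, and the single step available, a step that the two limits leave unreadable from compound 1 to compound 2, gives no size. With nothing but limits shown, no step beyond the scatter can be anticipated in either direction. Compound 3 is expected to remain near that limit, and its estimate is 25000 nM, between 8000 nM and 80000 nM. The step implied by this estimate is expected to be a step that the limit leaves unreadable from compound 2 to compound 3.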

Compound 3, half-maximal inhibitory concentration: 16000 nM
The estimate for compound 3 lay 1.6-fold (0.19 log units) above the measured number; measured number inside the range.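

Among the compounds shown here, compound 3 is the only one of the three compounds in this assay to give a measured number and not a limit, so the (6-(formylamino)hexyl)amino group gives this position its first readable value. Placing 4-(formylamino)butyl in place of hydroxy at this position gives an at least 1.2-fold lower number from compound 2 to compound 3 (0.09 log units; that floor lies within the scatter), which makes this change readable for the first time, though only as a floor and with no shift shown beyond the scatter. Placing 6-(formylamino)hexyl in place of 1-(hydroxymethyl)ethyl on the nitrogen gives an at least 1.2-fold lower number from compound 1 to compound 3 (0.09 log units; that floor lies within the scatter), and this too leaves open whether compound 3 differs from compound 1 by more than the scatter.

From the compounds shown here alone, neither step can be sized beyond its floor, and the step between compound 1 and compound 2 cannot be read at all, because each of these comparisons rests on a limit: the limit of > 20000 nM in this assay, at which 2 of the 3 values shown sit. Also open is whether the measured number follows the length of the chain or its formylamino end, which a hexyl chain ending in an amine or a carboxylic acid, or a longer chain with the same formylamino end, would help to separate.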